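This account rests on a few compounds, and the source may have more. Where it says the series, first, only, none or still open, it means among the compounds named here.

Compound 1 `COc1cc(-c2nn(-c3cccc(NC(=O)c4cccc(C(F)(F)F)c4)c3)cc2-c2ccncc2)ccc1Cl`: > 50000 nM
Compound 2 `COc1cc(-c2nn(-c3cccc(NC(=O)Nc4ccc(Cl)c(C(F)(F)F)c4)c3)cc2-c2ccncc2)ccc1Cl`: 11000 nM

In a functional assay on OVCAR-5 cells (Homo sapiens) for inhibition, read by sulforhodamine B assay, with a stated time of 48 h (a lower number here means a stronger inhibitor of growth, a higher number a weaker inhibitor of growth), compound 1 gives only a limit, > 50000 nM. In this assay, for the measured compounds named here, compound 2 gives 11000 nM, the only real number among the values shown. Going by the values given here, the single measured step is an at least 4.5-fold lower number from compound 1 to compound 2 (0.65 log units; beyond the scatter), and because it starts from the limit of > 50000 nM in this assay, at which 1 of the 2 values shown sits, its true size is not known. Compound 3 `COc1cc(-c2nn(-c3cccc(NC(=O)c4ccccc4)c3)cc2-c2ccncc2)ccc1Cl` differs from compound 2 by phenyl in place of (4-chloro-3-(trifluoromethyl)phenyl)amino on a carbonyl carbon. Among the compounds with values here, this change largely undoes the one that separated compound 1 from compound 2 and drops the trifluoromethyl as well, so compound 3 is closer in structure to compound 1. A step toward weaker growth inhibition in this assay is therefore expected, probably ending again at a limit. Compound 3 is estimated at 60000 nM, with a range from 20000 nM to 200000 nM. The expected step is a 5.5-fold higher number from compound 2 to compound 3 (0.74 log units; beyond the scatter).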

Compound 3, concentration for total growth inhibition: > 100000 nM
Compound 3 gave a limit, no number; the forecaster's own chance of this, stated with the estimate: 70%; at least 1.6-fold (0.22 log units) between middle value and limit.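

Putting phenyl in place of (4-chloro-3-(trifluoromethyl)phenyl)amino on a carbonyl carbon gives an at least 9.0-fold higher number from compound 2 to compound 3 (0.95 log units; beyond the scatter) in this assay, so removing this group weakens growth inhibition. From the compounds shown here alone, compound 3 gives only a limit, so the true size of that step stays unknown: the limit of > 100000 nM in this assay, at which 1 of the 3 values shown sits. Compound 1 also gives only a limit, so the step to compound 3, hydrogen in place of trifluoromethyl on an aromatic carbon, cannot be read: the limit of > 50000 nM in this assay, at which 1 of the 3 values shown sits.

Still open, going by these compounds, is which part of the group lost from compound 2 matters, since its amino link, chlorine and trifluoromethyl all leave together in this one change. Also open, on these data alone, is how a nitrile or a dimethylamino group on that aromatic ring would compare with the chlorine and trifluoromethyl of compound 2.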